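This account rests on a few compounds, and the source may have more. Where it says the series, first, only, none or still open, it means among the compounds named here.

Compound 1 `NC/C=C\CN(C[C@H]1Cc2ncccc2CN1)[C@H]1CCCc2cccnc21` is the reference point of this set. Among the compounds with values here, in an ADME assay for permeability, using PAMPA, with a stated time of 4 h, at pH 7.4 (a higher number here means that the compound crosses the layer faster, a lower number that the compound crosses the layer more slowly), compound 1 gives 68 nm/s, the highest of the three numbers so far. Compound 2 `NC/C=C/CN(C[C@H]1Cc2ncccc2CN1)[C@H]1CCCc2cccnc21` gives 15 nm/s in this assay, and compound 3 `c1cnc2c(c1)CN[C@@H](CN(CCCCNC1CCOCC1)[C@H]1CCCc3cccnc31)C2` gives 8 nm/s. The step of a 4.5-fold lower number from compound 1 to compound 2 (0.66 log units; beyond the scatter) rests on drawn geometry alone, because of the fact that compounds 1 and 2 differ only in the configuration as drawn. The step of an 8.5-fold lower number from compound 1 to compound 3 (0.93 log units; beyond the scatter) follows the exchange of the 3-aminoprop-1-en-1-yl group for a longer chain ending in an amine on a six-membered non-aromatic ring, while a 1.9-fold lower number from compound 2 to compound 3 (0.27 log units; within the scatter) stays within the scatter.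

Compound 4 `c1cnc2c(c1)CN[C@@H](CN(CCCC1CCNCC1)[C@H]1CCCc3cccnc31)C2` is not yet measured. Against compound 1 it shows (2-(piperidin-4-yl)ethyl in place of 3-aminoprop-1-en-1-yl on a saturated chain carbon bound to an amine nitrogen). Within the data shown here, the closest precedent is an 8.5-fold lower number from compound 1 to compound 3 (0.93 log units; beyond the scatter), where the same 3-aminoprop-1-en-1-yl group likewise gave way to a chain carrying a six-membered non-aromatic ring with 1 hetero atom. A downward step of comparable size, beyond the scatter, is therefore expected in this assay. For compound 4 the expected step is a 6.8-fold lower number from compound 1 to compound 4 (0.83 log units; beyond the scatter). Compound 4 is estimated at 10 nm/s, within a range of 3 nm/s to 30 nm/s.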

Compound 4, apparent permeability: 24 nm/s
Compound 4: middle estimate off by 2.4-fold (0.38 log units), on the low side; the range from low to high includes it.
By their numbers in this assay, from the lowest: compounds 3, 2 and 4 (each within the scatter of the next, the first and the last beyond it); then compound 1.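

The step of a 2.8-fold lower number from compound 1 to compound 4 (0.45 log units; beyond the scatter) is smaller than the one seen with the oxan-4-yl amine chain, so a chain carrying a six-membered non-aromatic ring does not fix one level at this saturated chain carbon bound to an amine nitrogen. What the chain carries counts in this assay: piperidin-4-yl in place of ((oxan-4-yl)amino)methyl gives a 3.0-fold higher number from compound 3 to compound 4 (0.48 log units; beyond the scatter). The saturated ring-bearing chain also cannot be told apart from the open chain drawn with the other double-bond geometry, with a 1.6-fold higher number from compound 2 to compound 4 (0.20 log units; within the scatter).

Still open, going by these compounds, is how a piperazine ring or an open saturated alkyl amine chain at this place would read in this assay. Nothing measured here bears on the reason for these steps.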